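The compounds below may be only part of what the source reports. "The series", "measured", "known", "first", "only" and "open" are said of these compounds alone.

Of the compounds shown here, three built on one shared core have so far been tested in a functional assay on HuTu80 cells (Homo sapiens) for cytotoxicity, read by MTT assay, with a stated time of 72 h; on this read-out lower numbers stand for an effect already at smaller amounts and higher numbers for an effect only at larger amounts of compound. Compound 1 `O=C1/C(=C\c2ccc(O)cc2)c2ccccc2N1c1c(Cl)cccc1Cl` carries a 4-hydroxyphenyl on a double-bonded chain carbon bound to a double-bonded ring carbon, and in this assay compound 1 gives 25 ug/mL, the highest of the three numbers. Compound 2 `O=C1/C(=C\c2cccc(Br)c2)c2ccccc2N1c1c(Cl)cccc1Cl` gives 7 ug/mL, and compound 3 `O=C1/C(=C\c2ccc(Cl)cc2)c2ccccc2N1c1c(Cl)cccc1Cl` gives 6 ug/mL. The step of a 3.6-fold lower number from compound 1 to compound 2 (0.55 log units; beyond the scatter) and the step of a 4.2-fold lower number from compound 1 to compound 3 (0.62 log units; beyond the scatter) point the same way, while the step of a 1.2-fold lower number from compound 2 to compound 3 (0.07 log units; within the scatter) shows that compound 2 and compound 3 cannot be told apart on these numbers.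

Compound 4 `O=C1/C(=C\c2cccc(Cl)c2)c2ccccc2N1c1c(Cl)cccc1Cl` has not yet been measured. It differs from compound 1 in one place: 3-chlorophenyl in place of 4-hydroxyphenyl on a double-bonded chain carbon bound to a double-bonded ring carbon. Among the measured compounds shown here, two measured steps bear on this change: the one from compound 1 to compound 2, where 3-bromophenyl replaced 4-hydroxyphenyl, and the one from compound 1 to compound 3, where chloro replaced hydroxy on an aromatic carbon. Both were modest and in the same direction, so a comparable modest lowering in this assay is expected for compound 4, namely the estimated step of a 3.6-fold lower number from compound 1 to compound 4 (0.55 log units; beyond the scatter). The estimate for compound 4 in this assay is therefore 7 ug/mL, with a range from 3.5 ug/mL to 14 ug/mL.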

Compound 4, concentration for half-maximal effect: 7 ug/mL
Beside the measured number, compound 4's estimate shows no gap at the digits printed, and the stated range covers the measured number.
By their numbers in this assay, from the lowest: compounds 3, 2 and 4 (each within the scatter of the next); then compound 1.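

In this assay, the step of a 3.6-fold lower number from compound 1 to compound 4 (0.55 log units; beyond the scatter) shows that 3-chlorophenyl in place of 4-hydroxyphenyl gives a lowering beyond the scatter, as the bromo and 4-chloro compounds did, so this position now has three halogen-bearing rings that all read lower than the hydroxy-bearing compound 1. Among the compounds shown here, the new compound also gives the first direct comparisons among those halogen-bearing rings: chloro in place of bromo gives no change at the digits printed from compound 2 to compound 4 (within the scatter), and 3-chlorophenyl in place of 4-chlorophenyl gives a 1.2-fold higher number from compound 3 to compound 4 (0.07 log units; within the scatter), so neither the choice between these two halogens nor the choice between these two chlorophenyl groups can be told apart here. For the compounds shown here, nothing measured so far accounts for why compound 1 stands apart from the other three.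

Going by these compounds, what remains open is whether the lowering follows the loss of the hydroxy or the arrival of a halogen, a question that a plain phenyl carrying neither group could help to separate. Also open, on these data alone, is how a ring bearing a methoxy or an amine would read in this assay.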